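The compounds below may be only part of what the source reports. "The series", "measured", "known", "first", "only" and "open" are said of these compounds alone.

Measured compounds in an ADME assay on Vero cells (Chlorocebus sabaeus) for cytotoxicity, read by MTT assay, with a stated time of 72 h; a higher number here means a weaker inhibitor, a lower number a stronger inhibitor:
compound 1 `Cc1ccc(-c2c(C#N)[n+]([O-])c3cc(C)c(C)cc3[n+]2[O-])cc1`: > 62.5 ug/mL
compound 2 `COc1ccc(-c2c(C#N)[n+]([O-])c3cc(C)c(C)cc3[n+]2[O-])cc1`: "not determined" (no result reported)
compound 3 `COC(=O)c1ccc(-c2c(C#N)[n+]([O-])c3cc(C)ccc3[n+]2[O-])cc1`: 3.2 ug/mL

Compound 3 stands as the only single number shown in this assay. The result for compound 1 is a limit of the assay rather than a number, and it is the one entry that sits at the limit of > 62.5 ug/mL in this assay, at which 1 of the 3 values shown sits. Compound 2 has no result to set beside the others. Among the compounds with values here, no two of the measured compounds differ in a single place, so no measured step in this assay is available to calibrate the change to the next compound.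

Compound 4 `COC(=O)c1ccc(-c2c(C#N)[n+]([O-])c3cc(C)c(C)cc3[n+]2[O-])cc1` differs from compound 3 by methyl in place of hydrogen on an aromatic carbon. Within the data shown here, nothing among the measured compounds shows what a methyl at this place does in this assay. Among the measured compounds shown here, with no measured step to lean on, the expectation is a change in this assay that stays within the usual scatter, in no particular direction. The step of a 1.1-fold higher number from compound 3 to compound 4 (0.04 log units; within the scatter) is therefore expected to be small. Compound 4 is expected to give about 3.5 ug/mL in this assay, with a plausible range from 1.4 ug/mL to 9 ug/mL, and the chance that the assay reports only a limit for compound 4 is judged low.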

Compound 4, half-maximal inhibitory concentration: 9.66 ug/mL
The estimate for compound 4 lay 2.8-fold (0.44 log units) below the measured number; measured number above the stated range.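

In this assay, within the data shown here, methyl in place of hydrogen on this aromatic carbon, ortho to a methyl group, gives the first measured change at this position, and it lies beyond the scatter: a 3.0-fold higher number from compound 3 to compound 4 (0.48 log units; beyond the scatter). The position therefore responds to even a single added carbon, with the number moving towards weaker inhibition and the second methyl not behaving as a silent change in this series. On the other side of the molecule, methoxycarbonyl in place of methyl on an aromatic carbon gives an at least 6.4-fold lower number from compound 1 to compound 4 (0.81 log units; beyond the scatter), which ties the methoxycarbonyl group to the lower number with the two methyl groups held constant, though this step gives only a bound, as the value for compound 1 is a limit of the assay: the limit of > 62.5 ug/mL in this assay, at which 1 of the 4 values shown sits.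

On these data alone, only methyl has been compared with hydrogen at this position, so it stays open whether an ethyl, a methoxy or an amine there would move the number further, or in the other direction. Also open, as far as these compounds go, is how a carboxylic acid or an amide in place of the methoxycarbonyl group would read in this assay.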